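Swapping a bromo-methoxy ring for a dimethoxy ring

The source may hold more compounds than are shown below. What is called first, only, known or untested is meant among the compounds shown, and "the series" means these compounds.

Among the compounds with values here, in an ADME assay on microsomes from liver (Rattus norvegicus) for metabolic stability, read by LC-MS, using NADPH, at 37 degrees C (a higher number here means that the compound lasts longer, a lower number that the compound disappears faster), compound 3 `COc1cccc(Br)c1-c1nc(CN2CCC(C(=O)NCCCN3C[C@H](C)C[C@H](C)C3)CC2)c(C)o1` gives 0.0583 h, the lowest of the three numbers measured so far. Compound 1 `Cc1oc(-c2ccccc2Cl)nc1CN1CCC(C(=O)NCCCN2C[C@H](C)C[C@H](C)C2)CC1` gives 0.25 h and compound 2 `Cc1oc(-c2c(F)cccc2F)nc1CN1CCC(C(=O)NCCCN2C[C@H](C)C[C@H](C)C2)CC1` gives 0.35 h; the steps were a 4.3-fold lower number from compound 1 to compound 3 (0.63 log units; beyond the scatter) and a 6.0-fold lower number from compound 2 to compound 3 (0.78 log units; beyond the scatter), both beyond the scatter, while a 1.4-fold higher number from compound 1 to compound 2 (0.15 log units; within the scatter) stayed within it. Compound 4 `COc1ccc(-c2nc(CN3CCC(C(=O)NCCCN4C[C@H](C)C[C@H](C)C4)CC3)c(C)o2)cc1OC` differs from compound 3 by 3,4-dimethoxyphenyl in place of 2-bromo-6-methoxyphenyl on an aromatic carbon. Moving away from the 2-bromo-6-methoxyphenyl is expected to raise the number because a 4.3-fold lower number from compound 1 to compound 3 (0.63 log units; beyond the scatter) and a 6.0-fold lower number from compound 2 to compound 3 (0.78 log units; beyond the scatter) were both drops into compound 3, but no measured compound carries a 3,4-dimethoxyphenyl, so the size of the gain is uncertain. Compound 4 is therefore expected to show a 2.6-fold higher number from compound 3 to compound 4 (0.41 log units; beyond the scatter), landing near 0.15 h, within 0.05 h to 0.45 h.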

Compound 4, half-life: > 0.5 h
Compound 4: a limit, no number; the forecaster's own chance of this, stated with the estimate: 5%; middle value at least 3.3-fold (0.52 log units) from the limit.
By their numbers in this assay, from the lowest: compound 3; then compounds 1 and 2 (each within the scatter of the next). At a limit, above all of these: compound 4.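

In this assay compound 4 gives a limit, not a number: the limit of > 0.5 h in this assay, at which 1 of the 4 values shown sits. At this position, 3,4-dimethoxyphenyl brings an at least 8.5-fold higher number from compound 3 to compound 4 (0.93 log units; beyond the scatter), so carrying methoxy groups on the phenyl ring does not by itself go with the low number of compound 3. The other steps are an at least 1.4-fold higher number from compound 2 to compound 4 (0.15 log units; that floor lies within the scatter) and an at least 2.0-fold higher number from compound 1 to compound 4 (0.30 log units; that floor lies within the scatter), and with both floors within the scatter, compound 4 cannot yet be set clearly apart from either compound.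

The compounds shown do not separate the bromine from the methoxy groups, and the true value of compound 4 remains unknown. Nor do they show how a phenyl ring carrying an amine or a carboxylic acid would behave here.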